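The source may hold more compounds than are shown below. What is called first, only, known or untested is meant among the compounds shown, and "the series" means these compounds.

Measured in a functional assay on HT cells (Homo sapiens) for antiproliferative activity, read by fluorescence, with a stated time of 72 h; a higher number here means a weaker inhibitor of growth, a lower number a stronger inhibitor of growth:
- compound 1 `CC(C)c1n[nH]c2c(NCc3ccc(-c4ccccn4)cc3)nc(SCC(N)CN)nc12`: 480 nM
- compound 2 `CC(C)c1n[nH]c2c(NCc3ccc(-c4ccccn4)cc3)nc(SCCO)nc12`: 48 nM
- compound 3 `CC(C)c1n[nH]c2c(NCc3ccc(-c4ccccn4)cc3)nc(SCC(O)CN3CCNCC3)nc12`: 332 nM

Compound 3 gives 332 nM, which lies within the scatter of its nearest neighbour (a 1.4-fold lower number from compound 1 to compound 3 (0.16 log units; within the scatter)). Its number is clearly higher than the remaining one (a 6.9-fold higher number from compound 2 to compound 3 (0.84 log units; beyond the scatter)).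

The next compound is compound 4 `CC(C)c1n[nH]c2c(NCc3ccc(-c4ccccn4)cc3)nc(SC(CO)C(C)C)nc12`. The change is 1-(hydroxymethyl)-2-methylpropyl in place of 2-hydroxy-3-(piperazin-1-yl)propyl on a sulfur, so the six-membered non-aromatic ring leaves.

Like compound 2, compound 4 has a hydroxy-bearing chain without nitrogen. Among the three measured compounds, the two with nitrogen in this chain both give higher numbers than compound 2 (a 10-fold lower number from compound 1 to compound 2 (1.00 log units; beyond the scatter) and a 6.9-fold higher number from compound 2 to compound 3 (0.84 log units; beyond the scatter)). Nothing measured here carries the branched chain of compound 4, so the size remains uncertain. A clear drop is therefore expected in this assay, close in size to those steps: a 5.5-fold lower number from compound 3 to compound 4 (0.74 log units; beyond the scatter).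

For compound 4 the estimated value is 60 nM, with an expected range of 20 nM to 180 nM.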

Compound 4, concentration for 50% growth inhibition: 980 nM
The estimate for compound 4 lay 16-fold (1.21 log units) below the measured number; measured number outside the range, above it.
By their numbers in this assay, from the lowest: compound 2; then compounds 3 and 1 (each within the scatter of the next); then compound 4.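

In this assay, adding isopropyl on the saturated chain carbon bound to the sulfur gives a large step (a 20-fold higher number from compound 2 to compound 4 (1.31 log units; beyond the scatter)), so a hydroxy-bearing chain without nitrogen does not by itself bring a low number. Among these compounds, compound 4 has no nitrogen and no ring in this chain, yet its number stands above those of both nitrogen-bearing compounds (a 3.0-fold higher number from compound 3 to compound 4 (0.47 log units; beyond the scatter); a 2.0-fold higher number from compound 1 to compound 4 (0.31 log units; beyond the scatter)), which leaves compound 2 as the only compound here in which a chain without nitrogen goes with a low number. Nothing available explains these steps.

From the compounds shown here alone, it remains open whether a smaller branch, such as a single methyl on that same chain carbon, would keep the number close to that of compound 2. Also open, going by these compounds, is how an amine in place of the hydroxyl on the branched chain would read.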